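The compounds below may be only part of what the source reports. "The series", "measured", "known", "first", "only" and "open" are said of these compounds alone.

Of the compounds shown here, three built on one shared core have been tested in a functional assay on HBL-100 cells (Homo sapiens) for inhibition, read by sulforhodamine B assay, with a stated time of 48 h; on this read-out lower numbers stand for stronger inhibition of growth and higher numbers for weaker inhibition of growth. Compound 1 `COC(=[Se])Nc1ccc2c(C)cc(=O)oc2c1` reaches only a limit of the assay there, > 100000 nM. Compound 2 `CCCOC(=[Se])Nc1ccc2c(C)cc(=O)oc2c1` gives 34000 nM. Compound 3 `CCCCOC(=[Se])Nc1ccc2c(C)cc(=O)oc2c1` gives "nd(insoluble)" (no result reported), so no number stands for it at all. Within the data shown here, of the three values shown, the one belonging to compound 1 sits at a limit of the assay, namely (the limit of > 100000 nM in this assay, at which 1 of the 3 values shown sits). Among the measured compounds shown here, the single measured step is an at least 2.9-fold lower number from compound 1 to compound 2 (0.46 log units; beyond the scatter). Compound 4 `Cc1cc(=O)oc2cc(NC(=[Se])Nc3ccccc3)ccc12` has not yet been tested in this assay. It differs from compound 3 by anilino in place of butoxy on a saturated chain carbon bound to a nitrogen on an aromatic ring. For the measured compounds named here, no measured step exchanges butoxy for anilino, so the step from compound 1 to compound 2 does not bear directly on this change, and compound 3 offers no number to step from. Any expectation therefore rests on the values of compound 1 and compound 2 alone, and no direction can be read from them for this exchange. In this assay compound 4 is expected to give 30000 nM, estimated to lie between 8000 nM and 100000 nM.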

Compound 4, concentration for 50% growth inhibition: 28000 nM
For compound 4 the middle estimate is 1.1-fold (0.03 log units) above the measured one, within the range that was stated.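

At this position, on a saturated chain carbon bound to a nitrogen on an aromatic ring, anilino does as well as propoxy in this assay: the exchange gives a 1.2-fold lower number from compound 2 to compound 4 (0.08 log units; within the scatter). An aromatic ring and a hydrogen-bond donor can therefore enter here in place of an oxygen-linked chain without losing the level set by propoxy, while the exchange for methoxy gives an at least 3.5-fold lower number from compound 1 to compound 4 (0.55 log units; beyond the scatter). That second step has a lower bound and no exact size, as compound 1 sits at a limit of the assay: the limit of > 100000 nM in this assay, at which 1 of the 4 values shown sits.

Compound 3 gives no number, which leaves open whether a chain longer than propoxy would change the reading. Also open, on these data alone, is how a simple amine such as dimethylamino, or an anilino ring carrying a carboxylic acid, would read at this place.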